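This account rests on a few compounds, and the source may have more. Where it says the series, first, only, none or still open, it means among the compounds named here.

Compound 2, `COC1=C(CC(C)(C)CNC(=O)c2ccccc2OC)C(=O)c2ccccc2C1=O`, was tested in a functional assay on KB cells (Homo sapiens) for cytotoxicity, read by resazurin assay, with a stated time of 3 days (a lower number here means a stronger inhibitor, a higher number a weaker inhibitor), and gave 33200 nM, which is the higher of the two values recorded. Among the measured compounds shown here, the only other measured compound, compound 1, `CC(C)(CNC(=O)c1ccc2ccccc2c1)CC1=C(O)C(=O)c2ccccc2C1=O`, carries a different core and a different amide substituent; in this assay compound 1 gives 9000 nM, a number separated from that of compound 2 by more than the usual scatter. For the measured compounds named here, since the two compounds differ in two places at once, their values show only that compound 1 sits lower, not what either change alone contributes.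

Compound 3, `COC1=C(CC(C)(C)CNC(=O)c2ccc3ccccc3c2)C(=O)c2ccccc2C1=O`, is the next compound, not yet measured. It keeps the core of compound 2 and changes the amide substituent: naphthalen-2-yl in place of 2-methoxyphenyl on a carbonyl carbon. Going by the values given here, the new substituent is the one found in compound 1. Among the compounds with values here, with no single-change step available, a modest move toward a lower number in this assay is expected, given that compound 1 with the same naphthalen-2-yl amide gives 9000 nM. Compound 3 is therefore estimated at 15000 nM, within the range 5000 nM to 45000 nM, an expected step of a 2.2-fold lower number from compound 2 to compound 3 (0.35 log units; beyond the scatter).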

Compound 3, half-maximal inhibitory concentration: 34100 nM
For compound 3 the middle estimate is 2.3-fold (0.36 log units) below the measured one; the range from low to high includes it.
By their numbers in this assay, from the lowest: compound 1; then compounds 2 and 3 (each within the scatter of the next).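

With the core of compound 2 kept, naphthalen-2-yl in place of 2-methoxyphenyl on a carbonyl carbon gives, in this assay, a 1.0-fold higher number from compound 2 to compound 3 (0.01 log units; within the scatter) and so does not separate the two compounds, even though the entering group has two six-membered aromatic rings of carbon only and no hydrogen-bond acceptor. With the naphthalen-2-yl amide kept, methyl in place of hydrogen on an oxygen on an unsaturated carbon gives a 3.8-fold higher number from compound 1 to compound 3 (0.58 log units; beyond the scatter) and so does separate the two compounds, a single-place comparison that the first two compounds could not offer. Among the compounds shown here, of the two single changes now readable, only the one on that oxygen gives a step beyond the scatter, and nothing at hand explains either step.

Still open, as far as these compounds go, is whether 2-methoxyphenyl and naphthalen-2-yl would also read alike on the core of compound 1, where that oxygen carries hydrogen. Also open, from the compounds shown here alone, is how an amide substituent carrying an amine or a carboxylic acid, or a longer chain in place of the methyl on the oxygen, would read in this assay on this shared core.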